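From iodo to methyl: a small expected step

The source may report more compounds than this note shows. Statements on the series, on what has been measured and on what is new or still open speak of the compounds shown alone.

In a functional assay on HT-29 cells (Homo sapiens) for inhibition, read by sulforhodamine B assay, with a stated time of 48 h (on this read-out lower numbers stand for stronger inhibition of growth and higher numbers for weaker inhibition of growth), as used here, compound 1 (`O=C(CCl)NC(=O)Nc1ccc(-c2ccccc2)cc1`) gives 2300 nM while compound 2 (`O=C(CCl)NC(=O)Nc1ccc(Oc2ccccc2)cc1`) gives 3600 nM and compound 3 (`O=C(CCl)NC(=O)Nc1ccc(I)cc1`) gives 6900 nM on the same scale. Two steps place compound 3 on this scale. One is a 1.9-fold higher number from compound 2 to compound 3 (0.28 log units; within the scatter) and so leaves it level with the phenoxy compound. The other is a 3.0-fold higher number from compound 1 to compound 3 (0.48 log units; beyond the scatter) and so sets it apart from the phenyl compound. Between the remaining pair lies a 1.6-fold higher number from compound 1 to compound 2 (0.19 log units; within the scatter) as well.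

The next compound, compound 4 (`Cc1ccc(NC(=O)NC(=O)CCl)cc1`), has methyl in place of iodo on an aromatic carbon. Going by the values given here, no measured step exchanges these two groups, so the evidence is indirect. All three steps change the same carbon, and the largest is modest. A small upward step is therefore expected in this assay and probably none beyond the scatter. The expected step is a 1.3-fold higher number from compound 3 to compound 4 (0.12 log units; within the scatter) on this estimate. Compound 4 is estimated at 9000 nM with a likely range from 4000 nM to 20000 nM in this test.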

Compound 4, concentration for 50% growth inhibition: 10000 nM
For compound 4 the middle estimate is 1.1-fold (0.05 log units) below the measured one; low and high end bracket the measured number.
By their numbers in this assay, from the lowest: compounds 1, 2, 3 and 4 (each within the scatter of the next, the first and the last beyond it).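

In this assay the exchange of iodo for methyl on this aromatic carbon leaves the two groups level (a 1.4-fold higher number from compound 3 to compound 4 (0.16 log units; within the scatter)), so between these two groups of one heavy atom each, this read-out shows no clear difference. Methyl also separates from both groups that carry a ring, phenoxy (a 2.8-fold higher number from compound 2 to compound 4 (0.44 log units; beyond the scatter)) and phenyl (a 4.3-fold higher number from compound 1 to compound 4 (0.64 log units; beyond the scatter)), whereas iodo stood clearly apart only from phenyl. Nothing measured here accounts for these differences.

The compounds shown leave open how this position would respond to a group of a different kind, such as an amine, a carboxylic acid or a longer chain. They also leave open whether the same differences between these groups would appear in other cell lines.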